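The source may report more compounds than this note shows. Statements on the series, on what has been measured and on what is new or still open speak of the compounds shown alone.

Compound 1 `COc1ccc(-c2cccc(=O)n2-c2cc(OC)c(OC)c(OC)c2)cc1`: < 10 nM, a limit.
Compound 2 `COc1cc(-n2c(-c3ccc([N+](=O)[O-])cc3)cccc2=O)cc(OC)c1OC`: < 10 nM, a limit.
Compound 3 `COc1cc(-n2c(-c3ccncc3)cccc2=O)cc(OC)c1OC`: 1780 nM.

Going by the values given here, in a functional assay on HepG2 cells (Homo sapiens) for cytotoxicity, read by spectrophotometry, with a stated time of 72 h (on this read-out lower numbers stand for stronger inhibition and higher numbers for weaker inhibition), compound 3 gives 1780 nM, the only true number in the set. The other two values are limits: the limit of < 10 nM in this assay, at which 2 of the 3 values shown sit. Two large steps separate them from compound 3: an at least 170-fold higher number from compound 1 to compound 3 (2.25 log units; beyond the scatter) and an at least 170-fold higher number from compound 2 to compound 3 (2.25 log units; beyond the scatter). Compound 4 `COc1cc(-n2c(-c3cccc(O)c3)cccc2=O)cc(OC)c1OC` carries this change: 3-hydroxyphenyl in place of pyridin-4-yl on an aromatic carbon. Its new ring is of carbon only, as in compound 1 and compound 2, which suggests a return towards their values. Among the compounds with values here, the swap between those two, a step that the two limits leave unreadable from compound 1 to compound 2, gives no size, and no measured compound carries 3-hydroxyphenyl, so a partial return is expected. The expected step is large and downward: a 30-fold lower number from compound 3 to compound 4 (1.47 log units; beyond the scatter). Compound 4 is estimated at 60 nM, within an expected range of 5 nM to 700 nM.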

Compound 4, half-maximal inhibitory concentration: 34 nM
Estimate against measurement, compound 4: 1.8-fold (0.25 log units) above, and the stated range covers the measured number.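

In this assay, 3-hydroxyphenyl recovers most of what pyridin-4-yl gives up at this position, with a 52-fold lower number from compound 3 to compound 4 (1.72 log units; beyond the scatter). The return is not shown to be complete, with an at least 3.4-fold higher number from compound 2 to compound 4 (0.53 log units; beyond the scatter) and an at least 3.4-fold higher number from compound 1 to compound 4 (0.53 log units; beyond the scatter). Compound 1 and compound 2 each stand at a limit and not at a number, so these two steps give only a minimum size: the limit of < 10 nM in this assay, at which 2 of the 4 values shown sit.

Still open, from the compounds shown here alone, is whether the hydroxyl itself matters or only the carbon-only ring, which a plain phenyl would separate. Going by these compounds, how an amine or a carboxylic acid in place of the hydroxyl would read is also open.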